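The source may hold more compounds than are shown below. What is called first, only, known or untested is meant among the compounds shown, and "the series" means these compounds.

The measured compounds:
compound 1, `CC(C)(C)OC(=O)N1CCC(Oc2cccc3c2CCN3c2ccc(S(C)(=O)=O)cc2)CC1`, 158 nM
compound 2, `CC(C)OC(=O)N1CCC(Oc2cccc3c2CCN3c2ccc(S(C)(=O)=O)cc2F)CC1`, 1000 nM
compound 3, `CCOC(=O)N1CCC(Oc2ncnc3c2CCN3c2ccc(S(C)(=O)=O)cc2F)CC1`, 251 nM

In a functional assay on CHO-K1 cells for agonist activity at Glucose-dependent insulinotropic receptor (Homo sapiens), read by a luciferase reporter, with a stated time of 5 h (a higher number here means that more compound is needed for the effect, a lower number that less compound is needed), compound 3 gives 251 nM. Among the three numbers this is the second highest. Its nearest neighbour is compound 1 at 158 nM; the gap between these two falls within the scatter of repeated measurements, so no order can be read from it. Compound 2, at 1000 nM, gives the furthest number, which lies beyond the scatter and is clearly higher than that of compound 3.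

The next compound, compound 4, `CC(C)SC(=O)N1CCC(Oc2ncnc3c2CCN3c2ccc(S(C)(=O)=O)cc2F)CC1`, keeps the core of compound 3 and alters the group on the carbonyl carbon: isopropylsulfanyl in place of ethoxy on a carbonyl carbon. Going by the values given here, no pair of measured compounds differs by this change alone, so the data give no direct guide to its size. The change is expected to leave this assay close to where compound 3 stands, with an expected step of a 1.2-fold higher number from compound 3 to compound 4 (0.08 log units; within the scatter), that is, none beyond the scatter in either direction. Compound 4 is therefore estimated at 300 nM, in a range from 100 nM to 1000 nM.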

Compound 4, half-maximal effective concentration: 10 nM
Beside the measured number, compound 4's estimate is 30-fold (1.48 log units) above it; the measured number lies below the stated range.
By their numbers in this assay, from the lowest: compound 4; then compounds 1 and 3 (each within the scatter of the next); then compound 2.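

Going by these compounds alone, the step of a 25-fold lower number from compound 3 to compound 4 (1.40 log units; beyond the scatter) in this assay shows that the group on the carbonyl carbon is a place where a single exchange can move the number far beyond the scatter, which the earlier compounds could not show, as no two of them differed in one place only. Ethoxy and isopropylsulfanyl differ both in the atom attached to the carbonyl carbon and in the chain that atom carries, so this one step cannot separate the two differences. Nothing at hand accounts for the size of the step.

From the compounds shown here alone, whether ethylsulfanyl on the same carbonyl carbon would stand nearer to ethoxy or to isopropylsulfanyl remains open, as does the standing of an isopropylamino group there. The compounds shown also leave open whether the step carries over to the core of compound 1.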